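A few compounds are considered here, and "the series" means these few. Any claim that something is new, unique, unknown or untested is made for them only; others in the source may bear on it.

Compound 1 `O=C1/C(=C/c2ccccc2F)CN(S(=O)(=O)c2ccc(F)cc2)C/C1=C\c1ccccc1F` and compound 2 `O=C1/C(=C/c2ccccc2F)CN(S(=O)(=O)c2ccc(Cl)cc2)C/C1=C\c1ccccc1F` share one core and differ only in a single aromatic substituent. In an ADME assay on L02 cells (Homo sapiens) for cytotoxicity, read by MTT assay, with a stated time of 24 h (on this read-out lower numbers stand for stronger inhibition and higher numbers for weaker inhibition), compound 1 gives 17500 nM, and compound 2 gives 14100 nM. The change between them, chloro in place of fluoro on an aromatic carbon, amounts to a 1.2-fold lower number from compound 1 to compound 2 (0.09 log units; within the scatter). Compound 2 therefore stands together with compound 1: the two values lie within the scatter of each other, and the numbers support no order between them.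

Compound 3 `N#Cc1ccc(S(=O)(=O)N2C/C(=C\c3ccccc3F)C(=O)/C(=C/c3ccccc3F)C2)cc1` carries the next change at the same place: cyano in place of chloro on an aromatic carbon. Among the measured compounds shown here, only one measured step bears on this position, the step from compound 1 to compound 2, and it stayed within the scatter. For the measured compounds named here, no measured compound carries a cyano group here, so the expectation rests on that single step alone. The account therefore expects compound 3 to remain close to compound 2, with an expected step of a 1.0-fold lower number from compound 2 to compound 3 (0.00 log units; within the scatter) in this assay. The estimate for compound 3 is 14000 nM, within an expected range from 6000 nM to 35000 nM.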

Compound 3, half-maximal inhibitory concentration: 11000 nM
Compound 3: the middle estimate sits 1.3-fold (0.10 log units) above what was measured; the range from low to high includes it.
By their numbers in this assay, from the lowest: compounds 3, 2 and 1 (each within the scatter of the next).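

In this assay, the position para to a large group on the aromatic ring now holds a third substituent, and the numbers still show no separation: cyano brings two heavy atoms, a triple bond and a hydrogen-bond acceptor where chloro has one heavy atom and no acceptor, yet the step stays within the scatter (a 1.3-fold lower number from compound 2 to compound 3 (0.11 log units; within the scatter)). The widest comparison available at this position, cyano against fluoro, also stays within the scatter (a 1.6-fold lower number from compound 1 to compound 3 (0.20 log units; within the scatter)), so compounds 1, 2 and 3 form one group in which this read-out supports no order, and a change from a single halogen atom to a two-atom nitrile leaves no measurable mark here. No supporting measurement is available that could explain why these values stay together.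

The compounds shown leave open whether a substituent of another kind at this position, such as an amine, a carboxylic acid or a longer alkyl chain, would stay within the scatter as well. They also leave open how the read-out responds to changes elsewhere, since all three compounds share the same core and the same two 2-fluorophenyl-bearing arms.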